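The compounds below may be only part of what the source reports. "The series", "measured", "known", "first", "only" and "open" are said of these compounds alone.

Going by the values given here, compound 1 `CN(C)Cc1cc(/C=C/C(=O)/C=C(O)/C=C/c2ccc(O)cc2)ccc1O` gives 7600 nM in a functional assay, with a stated time of 19 h (a lower number here means a stronger inhibitor, a higher number a weaker inhibitor), the highest of the two numbers so far. Compound 2 `CN(C)Cc1cc(/C=C/C(=O)/C=C(O)/C=C/c2cccc(O)c2)ccc1O` gives 6900 nM in this assay, and the step of a 1.1-fold lower number from compound 1 to compound 2 (0.04 log units; within the scatter) lies within the scatter. Compound 3 `CN(C)Cc1cc(/C=C/C(=O)/C=C(O)/C=C/c2ccc(Cl)cc2)ccc1O` differs from compound 1 by chloro in place of hydroxy on an aromatic carbon. Among the compounds with values here, no measured step concerns a hydroxy replaced by chloro; the only step at hand, 3-hydroxyphenyl in place of 4-hydroxyphenyl, is within the scatter and gives no direction. For compound 3 a step of a 1.0-fold lower number from compound 1 to compound 3 (0.01 log units; within the scatter) within the scatter is expected. Compound 3 is therefore estimated at 7500 nM, ranging from 3000 nM to 19000 nM.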

Compound 3, half-maximal inhibitory concentration: 41100 nM
Estimate against measurement, compound 3: 5.5-fold (0.74 log units) below; measured number outside the range, above it.
By their numbers in this assay, from the lowest: compounds 2 and 1 (each within the scatter of the next); then compound 3.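

In this assay chloro in place of hydroxy on this aromatic carbon brings a 5.4-fold higher number from compound 1 to compound 3 (0.73 log units; beyond the scatter) and 4-chlorophenyl in place of 3-hydroxyphenyl brings a 6.0-fold higher number from compound 2 to compound 3 (0.77 log units; beyond the scatter) with the same direction. The ring thus accepts hydroxy at either position shown, while the one change to chloro, which carries no hydrogen-bond donor or acceptor, gives a weaker inhibitor. No measurement on hand accounts for this loss. Still open, as far as these compounds go, is whether methoxy or an amine on this carbon behaves like hydroxy or like chloro, and whether fluoro does the same.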